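Nitro for methoxy on the benzamide of compound 3

The source may hold more compounds than are shown below. What is called first, only, known or untested is meant among the compounds shown, and "the series" means these compounds.

The shared core is a 2-substituted benzothiazole bearing a methoxy group, as in compound 3 `COc1ccc(C(=O)Nc2nc3c(OC)cccc3s2)cc1` and compound 2 `COc1cccc2sc(NC(=O)c3ccc(C(F)(F)F)cc3)nc12`; compound 1 `O=C(Nc1cccc([N+](=O)[O-])c1)Nc1nc2ccc(Cl)cc2s1` is a urea analogue on a chloro-substituted core. In a functional assay on SK-HEP1 cells (Homo sapiens) for antiproliferative activity, read by sulforhodamine B assay (a higher number here means a weaker inhibitor of growth, a lower number a stronger inhibitor of growth), compound 3 gives 2.11 ug/mL, the lowest of the two numbers reported. Compound 1 gives 2.21 ug/mL in this assay, within the scatter of compound 3, so no order between the two can be stated. Compound 2 reaches only the limit of this assay, > 10 ug/mL, as stated in the limit of > 10 ug/mL in this assay, at which 1 of the 3 values shown sits. Within the data shown here, the one measured step, an at least 4.7-fold lower number from compound 2 to compound 3 (0.67 log units; beyond the scatter), shows that exchanging the trifluoromethyl for methoxy lowers the number in this assay by at least a modest amount.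

Compound 4 `COc1cccc2sc(NC(=O)c3ccc([N+](=O)[O-])cc3)nc12` differs from compound 3 by nitro in place of methoxy on an aromatic carbon. Among the measured compounds shown here, no measured step covers a nitro at this place; compound 1 carries a nitro on a different scaffold and gives a number close to compound 3. For the measured compounds named here, the only related step, from compound 2 to compound 3, moved away from a group other than methoxy, so a modest rise in number is expected for compound 4, a 1.9-fold higher number from compound 3 to compound 4 (0.28 log units; within the scatter), still short of the limit. Compound 4 is therefore estimated at 4 ug/mL, with a range from 1.5 ug/mL to 10 ug/mL.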

Compound 4, concentration for 50% growth inhibition: > 10 ug/mL
Compound 4 ended at the assay's limit; the forecaster's own chance of this, stated with the estimate: 20%; middle value at least 2.5-fold (0.39 log units) from the limit.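

Nitro in place of methoxy on the benzamide, para to a large group, gives an at least 4.7-fold higher number from compound 3 to compound 4 (0.67 log units; beyond the scatter) in this assay. Together with an at least 4.7-fold lower number from compound 2 to compound 3 (0.67 log units; beyond the scatter), this places methoxy ahead of two different replacements at this position on the shared core, so the number of compound 3 depends on the methoxy and is not carried by the core alone. Trifluoromethyl and nitro cannot be ordered against each other, and the step between compound 2 and compound 4 cannot be read, since both values are limits of the assay and not numbers: the limit of > 10 ug/mL in this assay, at which 2 of the 4 values shown sit.

As far as these compounds go, with compound 3 at 2.11 ug/mL, it remains open whether an amine or a hydroxyl at this position, or a longer chain such as ethoxy in place of methoxy, would keep a number in that range. Also open is whether the loss seen with nitro and trifluoromethyl holds at other places on the benzamide ring, since the compounds shown vary this one position only.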